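The source may report more compounds than this note shows. Statements on the series, on what has been measured and on what is new or still open speak of the compounds shown alone.

Measured compounds:
compound 1 `COc1ccc(Br)cc1NC(=O)CN1CCN(S(=O)(=O)N2CCC(C)CC2)CC1` — 1400 nM
compound 2 `COc1ccc(Cl)cc1NC(=O)CN1CCN(S(=O)(=O)N2CCC(C)CC2)C[C@@H]1C` — 3500 nM
compound 3 `COc1ccc(Cl)cc1NC(=O)CN1CCN(S(=O)(=O)N2CCC(C)CC2)C[C@H]1C` — 2400 nM

In an assay on HEK293 cells for inhibition of potassium channel subfamily T member 1 (Homo sapiens), read by thallium flux (a lower number here means a stronger inhibitor, a higher number a weaker inhibitor), compound 1 gives the lowest of the three numbers; compound 3 lies within the scatter of it, compound 2 beyond. Compound 4 `COc1ccc(C)cc1NC(=O)CN1CCN(S(=O)(=O)N2CCC(C)CC2)CC1` has not been measured; it differs from compound 1 by methyl in place of bromo on an aromatic carbon. For the measured compounds named here, the only measured step is a 1.5-fold lower number from compound 2 to compound 3 (0.16 log units; within the scatter), which rests on a change of configuration at a saturated ring carbon (the fact that compounds 2 and 3 differ only in the configuration as drawn); no measured pair changes a substituent on the aromatic ring, so no step bears directly on the change to compound 4. Compound 4 is therefore expected to give 2500 nM, with a range from 900 nM to 7000 nM. This estimate means a 1.8-fold higher number from compound 1 to compound 4 (0.25 log units; within the scatter), a step that may or may not reach beyond the scatter.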

Compound 4, half-maximal inhibitory concentration: > 10000 nM
Compound 4: only a limit was reported; the forecaster's own chance of this, stated with the estimate: 5%; middle value at least 4.0-fold (0.60 log units) from the limit.
By their numbers in this assay, from the lowest: compounds 1, 3 and 2 (each within the scatter of the next, the first and the last beyond it). At a limit, above all of these: compound 4.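

In this assay, the substituent on the aromatic carbon para to the methoxy group proves decisive, with methyl in place of bromo giving an at least 7.1-fold higher number from compound 1 to compound 4 (0.85 log units; beyond the scatter). No earlier pair isolated a change at this position, since the only listed step concerned configuration at a saturated ring carbon. The value of compound 4 (> 10000 nM) is a limit, so the step has only a lower bound: the limit of > 10000 nM in this assay, at which 1 of the 4 values shown sits.

Open, as far as these compounds go, is how a trifluoromethyl, a nitrile or a plain hydrogen at this position would read on the core of compound 1. Methyl and bromo stand far apart here. These data offer no explanation for that gap.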